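From a branched chain to a benzyl group

The compounds below may be only part of what the source reports. "The series", "measured", "known", "first", "only" and "open" are said of these compounds alone.

Compound 1 `CC(C)CCn1nc(CC2=CCCC2)c(O)c(C2=NS(=O)(=O)c3cc(NS(C)(=O)=O)ccc3N2)c1=O`: in an in vitro ADME assay on microsomes from liver (Homo sapiens) for metabolic stability, tested at 5 uM (a higher number here means that the compound lasts longer, a lower number that the compound disappears faster), compound 1 gives 0.15 h.
Compound 2 `CCC(C)CCn1nc(-c2cccs2)c(O)c(C2=NS(=O)(=O)c3cc(NS(C)(=O)=O)ccc3N2)c1=O`: in this assay compound 2 gives > 1 h, which is a limit of the assay and not a number.

Compound 2 therefore stands at the upper edge of what this assay can report: the limit of > 1 h in this assay, at which 1 of the 2 values shown sits. Compound 3, `CS(=O)(=O)Nc1ccc2c(c1)S(=O)(=O)N=C(c1c(O)c(-c3cccs3)nn(Cc3ccccc3)c1=O)N2`, differs from compound 2 by phenyl in place of 2-methylbutyl on a saturated chain carbon bound to an aromatic nitrogen. Among the compounds with values here, no measured pair shows this change, so its effect in this assay is open; a shift no larger than the scatter, in either direction, is the expectation. Compound 3 is expected to give 0.9 h, between 0.4 h and 2 h, an expected step of an at least 1.1-fold lower number from compound 2 to compound 3 (0.04 log units; that floor lies within the scatter) that may still end at the limit.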

Compound 3, half-life: > 1 h
Compound 3 gave a limit, no number (the forecaster's own chance of this, stated with the estimate: 40%); middle value at least 1.1-fold (0.04 log units) from the limit.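

No step can be read from compound 2 to compound 3, since each gives a limit of the assay and not a number: the limit of > 1 h in this assay, at which 2 of the 3 values shown sit.

Going by these compounds, whether phenyl in place of 2-methylbutyl shifts the half-life at all in this assay stays open.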